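The compounds below may be only part of what the source reports. "The series", "measured", "known", "first", "only" and "open" are said of these compounds alone.

In a functional assay on MCF7 cells (Homo sapiens) for antiproliferative activity, read by CellTiter-Glo, with a stated time of 5 days (a lower number here means a stronger inhibitor, a higher number a weaker inhibitor), three compounds on a shared core have been measured. Compound 3 (`CC1=C(c2cccc(O)c2)C(c2ccc(OC[C@H](C)N3CC[C@@H](C)C3)cc2)Oc2ccc(O)cc21`) gives 0.2 nM and compound 1 (`CC1=C(c2cccc(O)c2)C(c2ccc(OC[C@@H](C)N3CCCC3)cc2)Oc2ccc(O)cc21`) gives 0.2 nM, so these two stand level at the lowest number of the set, while compound 2 (`CC1=C(c2cccc(S(C)(=O)=O)c2)C(c2ccc(OC[C@H](C)N3CC[C@@H](C)C3)cc2)Oc2ccc(O)cc21`) gives 4.3 nM. Compound 4 (`CC1=C(c2cccc(F)c2)C(c2ccc(OC[C@H](C)N3CC[C@@H](C)C3)cc2)Oc2ccc(O)cc21`) keeps everything in compound 3 except one group: fluoro in place of hydroxy on an aromatic carbon. Fluoro takes the place of hydroxy on an aromatic carbon, turning 3-hydroxyphenyl into 3-fluorophenyl.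

Two measured steps can be weighed here. The change on the saturated chain carbon, no change at the digits printed from compound 1 to compound 3 (within the scatter), lies elsewhere in the structure and offers little guidance. The change at the aromatic carbon itself, hydroxy in place of methylsulfonyl, is the closer guide, and it gave a 22-fold lower number from compound 2 to compound 3 (1.33 log units; beyond the scatter). Going by the values given here, no measured compound carries fluoro at this place, so how it ranks against either group remains open. Resting on that large step from compound 2, a move to a higher number is expected on leaving hydroxy, though a smaller one. The estimated step is a 5.0-fold higher number from compound 3 to compound 4 (0.70 log units; beyond the scatter). For compound 4 the expected value is 1 nM, with an estimated range from 0.3 nM to 4 nM.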

Compound 4, half-maximal inhibitory concentration: 1 nM
Beside the measured number, compound 4's estimate shows no gap at the digits printed, within the range that was stated.
By their numbers in this assay, from the lowest: compounds 1 and 3 (each within the scatter of the next); then compound 4; then compound 2.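

Across this assay, leaving hydroxy for fluoro at this place gives a 5.0-fold higher number from compound 3 to compound 4 (0.70 log units; beyond the scatter) and so has a cost beyond the scatter, though a modest one, which shows that hydroxy is not needed for a number this low. Fluoro also keeps much of what methylsulfonyl lost, with a 4.3-fold lower number from compound 2 to compound 4 (0.63 log units; beyond the scatter) on the same core and side chain, so the three groups at this aromatic carbon now fall in a measured order of hydroxy, then fluoro, then methylsulfonyl, where the earlier compounds gave only the two ends of that order. Nothing measured here accounts for this order, and the counted loss of a hydrogen-bond donor and acceptor on going to fluoro stands only as a difference between the two structures.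

On these data alone, it remains open whether a methoxy group, a chlorine atom or an amino group at this place would fall near hydroxy, near fluoro or outside that order. The shown compounds also leave open whether the step from hydroxy to fluoro would keep its size on the side chain of compound 1, which carries the unsubstituted five-membered ring.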